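A few compounds are considered here, and "the series" means these few. Any claim that something is new, unique, unknown or untested is made for them only; others in the source may bear on it.

In an assay on HeLa cells for binding affinity to 5-hydroxytryptamine receptor 6 (Homo sapiens) (a higher number here means a weaker inhibitor, a lower number a stronger inhibitor), three compounds have been measured:

compound 1 `COc1ccc(NS(=O)(=O)c2ccc3c(Cl)cccc3c2)cc1N1CCN(C)CC1` gave 0.794 nM
compound 2 `COc1ccc(NS(=O)(=O)c2ccc(Br)cc2)cc1N1CCN(C)CC1` gave 5.01 nM
compound 3 `COc1ccc(NS(=O)(=O)c2c(C)sc3ccc(Cl)cc23)cc1N1CCN(C)CC1` gave 1.26 nM

Compound 2 stands highest of the three, beyond the scatter from both compound 3 and compound 1. Compound 4 `COc1ccc(NS(=O)(=O)c2cn(C)cn2)cc1N1CCN(C)CC1` is not yet measured in this assay. It differs from compound 2 in one place: 1-methyl-1H-imidazol-4-yl in place of 4-bromophenyl on a sulfonyl sulfur. Going by the values given here, no measured pair shows this change, so its size is not known from the data. The shared core being unchanged, the step of a 6.0-fold higher number from compound 2 to compound 4 (0.78 log units; beyond the scatter) is expected to move upward, with a fair chance it falls within the scatter. Compound 4 is therefore estimated at 30 nM, in a range from 5 nM to 200 nM.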

Compound 4, inhibition constant: 794 nM
For compound 4 the middle estimate is 26-fold (1.42 log units) below the measured one, outside the stated range (above it).
By their numbers in this assay, from the lowest: compounds 1 and 3 (each within the scatter of the next); then compound 2; then compound 4.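

In this assay, the group on the sulfonyl sulfur proves decisive: 1-methyl-1H-imidazol-4-yl in place of 4-bromophenyl gives a 160-fold higher number from compound 2 to compound 4 (2.20 log units; beyond the scatter) and is a large step. Going by these compounds alone, the earlier compounds offered no step in one place, so this is the first size that can be read for any change here. Nothing measured on these compounds explains the rise.

Still open, as far as these compounds go, is which part of the change carries the step: the five-membered ring, its two nitrogens or the missing bromine. An unsubstituted phenyl or a pyridine ring on the sulfonyl sulfur would help separate these.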